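Swapping cyclohexyl for trifluoromethyl on a sigma-1 ligand

This account rests on a few compounds, and the source may have more. Where it says the series, first, only, none or still open, it means among the compounds named here.

Measured so far in an assay on membranes from Jurkat cells for displacement of a labelled ligand from Sigma non-opioid intracellular receptor 1 (Homo sapiens), read by scintillation counting, with a stated time of 2 h; a lower number here means a stronger inhibitor, a higher number a weaker inhibitor:
compound 1 `Cn1nc(CN2CCCC2)nc1-c1ccc2c(c1)CCCC2` gives 26 nM;
compound 2 `Cn1nc(CN2CCCC2)nc1-c1ccc(C2CCCCC2)cc1` gives 20 nM;
compound 3 `Cn1nc(CN2CCCC2)nc1-c1ccc2ccsc2c1` gives 64 nM.

Compound 2 has the lowest number of the three, but compound 1 sits within the usual scatter of it, so the two cannot be ordered. Only compound 3 stands clearly apart, with a higher number beyond the scatter.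

Compound 4 `Cn1nc(CN2CCCC2)nc1-c1ccc(C(F)(F)F)cc1` is not yet measured. It differs from compound 2 in one place: trifluoromethyl in place of cyclohexyl on an aromatic carbon. All three measured compounds carry a large ring-bearing group there, so the data give no direct guide to a small substituent. The step is expected to be a modest weakening in this assay, a 3.0-fold higher number from compound 2 to compound 4 (0.48 log units; beyond the scatter), but could also fall within the scatter. For compound 4 the expected value is 60 nM, with a range from 20 nM to 180 nM.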

Compound 4, inhibition constant: 82 nM
Compound 4: middle estimate off by 1.4-fold (0.14 log units), on the low side; measured number inside the range.
By their numbers in this assay, from the lowest: compounds 2 and 1 (each within the scatter of the next); then compounds 3 and 4 (each within the scatter of the next).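

For the compounds shown here, putting trifluoromethyl in place of cyclohexyl on this aromatic carbon produces a 4.1-fold higher number from compound 2 to compound 4 (0.61 log units; beyond the scatter) in this assay and gives the first direct reading of a group without a ring here. The position tolerates this smaller group, so a ring is not required for binding to be measured, but compound 4 is clearly weaker than compound 2. Nothing available explains this weakening.

On these data alone, what a methyl group, a single fluorine atom, an amine or a carboxylic acid would do at this position remains open. A longer carbon chain is also untested among the compounds shown, so it is unclear whether size alone tracks these numbers.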